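Swapping isopropyl for 4-chlorophenyl on the ring nitrogen

The source may report more compounds than this note shows. Statements on the series, on what has been measured and on what is new or still open speak of the compounds shown alone.

In a functional assay on HeLa cells (Homo sapiens) for antiproliferative activity, read by MTT assay, with a stated time of 72 h (on this read-out lower numbers stand for stronger inhibition and higher numbers for weaker inhibition), compound 3 `CC(C)N1C(=O)COc2ccc(-c3cnc(Cl)c(NS(=O)(=O)c4ccc(F)cc4)c3)cc21` gives 5380 nM and compound 1 `COc1ncc(-c2ccc3c(c2)N(c2ccc(C)cc2)C(=O)CO3)cc1NS(=O)(=O)c1ccc(F)cc1` gives 4650 nM, two values within the scatter of each other. Compound 2 `COc1cccc(N2C(=O)COc3ccc(-c4cnc(OC)c(NS(=O)(=O)c5ccc(F)cc5)c4)cc32)c1` reaches only a limit, > 40000 nM.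

Compound 4 `O=C1COc2ccc(-c3cnc(Cl)c(NS(=O)(=O)c4ccc(F)cc4)c3)cc2N1c1ccc(Cl)cc1` keeps the rest of compound 3 but has 4-chlorophenyl in place of isopropyl on the amide-type nitrogen in a ring: 4-chlorophenyl in place of isopropyl on an amide-type nitrogen in a ring.

Among the compounds with values here, the one measured step at this nitrogen is an at least 8.6-fold higher number from compound 1 to compound 2 (0.93 log units; beyond the scatter), with 3-methoxyphenyl in place of 4-methylphenyl, and it lies beyond the scatter. The group on this nitrogen can therefore matter, but that step does not involve isopropyl or 4-chlorophenyl. Compound 1, with 4-methylphenyl, gives 4650 nM, so a substituted phenyl at this nitrogen need not cost activity. The expectation is no change beyond the scatter, with a wide margin on the weaker side.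

The estimated step is a 1.1-fold higher number from compound 3 to compound 4 (0.05 log units; within the scatter). For compound 4 the expected value is 6000 nM, with an estimated range from 1800 nM to 25000 nM.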

Compound 4, half-maximal inhibitory concentration: > 40000 nM
Compound 4: a limit, no number; the forecaster's own chance of this, stated with the estimate: 15%; at least 6.6-fold (0.82 log units) between middle value and limit.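

In this assay, within the data shown here, the change on the amide-type nitrogen gives an at least 7.4-fold higher number from compound 3 to compound 4 (0.87 log units; beyond the scatter), the first step at this position that involves isopropyl or 4-chlorophenyl and the first on the shared core of compound 3. The value of compound 4 is a limit, not a number. With the earlier step of an at least 8.6-fold higher number from compound 1 to compound 2 (0.93 log units; beyond the scatter), two single changes at this nitrogen now lie beyond the scatter, each on its own core, and the size of neither can be fixed: the limit of > 40000 nM in this assay, at which 2 of the 4 values shown sit.

The compounds shown do not separate the 4-chlorophenyl ring from its chlorine as the source of this step, since the unsubstituted phenyl is not among them. Going by these compounds, how a longer alkyl chain, or a chain ending in an amine or a carboxylic acid, would behave on this nitrogen also remains open.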